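Swapping the ring on the branched carbon of compound 3

The source may report more compounds than this note shows. Statements on the series, on what has been measured and on what is new or still open speak of the compounds shown alone.

Compound 3 `CC(C)C(c1ccc(-c2ccc3cccc(F)c3c2)[nH]c1=O)N1CCN/C1=N\C#N` holds the highest number of the three measured compounds in an ADME assay on microsomes from liver (Homo sapiens) for metabolic stability (on this read-out lower numbers stand for a shorter-lived compound and higher numbers for a longer-lived compound), giving 0.632 h. Compound 2 `CC(C)C(c1ccc(-c2ccc3cccc(F)c3c2)[nH]c1=O)N1CCCCC1=O` gives 0.183 h and compound 1 `CC(C)C(Cc1ncc[nH]1)c1ccc(-c2ccc3cccc(F)c3c2)[nH]c1=O` gives 0.106 h. Compound 4 `CC(C)C(Cc1noc(=O)[nH]1)c1ccc(-c2ccc3cccc(F)c3c2)[nH]c1=O` differs from compound 3 by a group of 7 heavy atoms (3 carbon, 2 nitrogen, 2 oxygen; one five-membered aromatic ring with 3 hetero atoms) in place of a group of 8 heavy atoms (4 carbon, 4 nitrogen; one five-membered non-aromatic ring with 2 hetero atoms), on a saturated chain carbon bound to an aromatic carbon and a saturated chain carbon. For the measured compounds named here, the steps that bear on this are a 6.0-fold higher number from compound 1 to compound 3 (0.78 log units; beyond the scatter) and a 3.5-fold higher number from compound 2 to compound 3 (0.54 log units; beyond the scatter), which show that the group present in compound 3 carries the longest half-life seen here. Since compound 4 returns to a five-membered aromatic ring on that carbon, as in compound 1, a step downward beyond the scatter is expected, a 3.2-fold lower number from compound 3 to compound 4 (0.50 log units; beyond the scatter). Compound 4 is estimated at 0.2 h, within a range of 0.08 h to 0.5 h.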

Compound 4, half-life: > 3 h
Compound 4 was reported as a limit; the forecaster's own chance of this, stated with the estimate: 5%; middle value at least 15-fold (1.17 log units) away from the limit.
By their numbers in this assay, from the lowest: compounds 1 and 2 (each within the scatter of the next); then compound 3. At a limit, above all of these: compound 4.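

In this assay compound 4 stands only as a limit: the limit of > 3 h in this assay, at which 1 of the 4 values shown sits.

Its ring outlasts the non-aromatic rings, with an at least 4.7-fold higher number from compound 3 to compound 4 (0.67 log units; beyond the scatter) and an at least 16-fold higher number from compound 2 to compound 4 (1.21 log units; beyond the scatter), so the longest half-life no longer belongs to the group in compound 3. A five-membered aromatic ring at this place therefore does not by itself mean a short half-life, since changing that ring on the same chain gives an at least 28-fold higher number from compound 1 to compound 4 (1.45 log units; beyond the scatter).

From the compounds shown here alone, the true size of these steps stays open. So does whether a carboxylic acid on the same chain would behave like the ring in compound 4.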